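Open-chain dithiol in place of the ring-closed disulfide

The source may hold more compounds than are shown below. What is called first, only, known or untested is meant among the compounds shown, and "the series" means these compounds.

Three compounds of the series have numbers in a functional assay on HT-22 cells (Mus musculus), with a stated time of 24 h; a lower number here means that less compound is needed, a higher number that more compound is needed for the effect. Compound 1 `Oc1ccc(-c2noc(CCCCC3CCSS3)n2)cc1O` gives 3630 nM in this assay. Compound 2 `Oc1ccc(CCc2nnc(CCCCC3CCSS3)o2)cc1O` gives 4210 nM in this assay. Compound 3 `Oc1ccc(-c2cc(CCCCCC3CCSS3)n[nH]2)cc1O` gives 6230 nM in this assay. Compound 3 has the highest of the three numbers, but its gaps to compound 2 and to compound 1 both lie within the scatter, so the three stand together and no order among them can be read.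

Compound 4 `Oc1ccc(-c2cc(CCCCCC(S)CCS)n[nH]2)cc1O` differs from compound 3 by a group of 5 heavy atoms (3 carbon, 2 sulfur; no ring) in place of a group of 5 heavy atoms (3 carbon, 2 sulfur; one five-membered non-aromatic ring with 2 hetero atoms), on a saturated chain carbon, five bonds along the chain from an aromatic carbon. The five-membered ring with two hetero atoms is opened into the 1,3-disulfanylpropyl group, with two hydrogen-bond donors entering where there were none. Among the measured compounds shown here, no measured pair shows a change of this kind, so nothing in the numbers fixes its size. The expected step is a 1.4-fold lower number from compound 3 to compound 4 (0.14 log units; within the scatter), not beyond the scatter, given that the three measured compounds with the ring sit so close together. Compound 4 is estimated at 4500 nM, with a range from 1500 nM to 13000 nM.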

Compound 4, half-maximal effective concentration: > 10000 nM
Compound 4 gave a limit, no number; the forecaster's own chance of this, stated with the estimate: 5%; middle value at least 2.2-fold (0.34 log units) from the limit.
By their numbers in this assay, from the lowest: compounds 1, 2 and 3 (each within the scatter of the next). At a limit, above all of these: compound 4.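

Opening the five-membered ring into the 1,3-disulfanylpropyl group, on a saturated chain carbon, gives the first compound of the series without a number in this assay. Compound 4 stands at a limit of the assay, not at a number: the limit of > 10000 nM in this assay, at which 1 of the 4 values shown sits. The change gives an at least 1.6-fold higher number from compound 3 to compound 4 (0.20 log units; that floor lies within the scatter), so the two hydrogen-bond donors entering with the open chain bring no lower number at this position, while the floor alone does not show a loss beyond the scatter.

From the compounds shown here alone, the true size of the step stays open, as does the outcome of the same ring opening on the cores of compound 1 and compound 2. Also open, going by these compounds, is how a carboxylic acid or an amine in place of the ring would read in this assay.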